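A few compounds are considered here, and "the series" means these few. Any claim that something is new, unique, unknown or untested is made for them only; others in the source may bear on it.

Measured compounds in a functional assay on SK-OV-3 cells (Homo sapiens) for inhibition, read by sulforhodamine B assay, with a stated time of 48 h; a lower number here means that less compound is tolerated, a higher number that more compound is tolerated:

compound 1 `Nc1cc(N)c2nc(-c3ccccc3)c(NCc3ccc(Cl)c(Cl)c3)nc2c1` gives 69200 nM
compound 2 `COc1cc(CNc2nc3cc(N)cc(N)c3nc2-c2ccccc2)cc(OC)c1OC` gives 36300 nM
compound 3 `COc1ccc(Sc2nc3cc(N)cc(N)c3nc2-c2ccccc2)cc1` gives < 100000 nM, which is a limit of the assay and not a number

Compound 1 and compound 2 carry a benzylamine-type substituent on the shared core, compound 3 a thioether. Both numbered values sit in the weak range of this assay, and the gap between compound 1 and compound 2 is not large. Compound 3 stands only on the limit (the limit of < 100000 nM in this assay, at which 1 of the 3 values shown sits); where it lies within the range the limit allows is not known from the numbers shown, so no ordering against compound 1 or compound 2 can be read from it.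

Compound 4 `Nc1cc(N)c2nc(-c3ccccc3)c(Oc3ccc(F)cc3)nc2c1` is not yet measured. It differs from compound 3 in one place: 4-fluorophenoxy in place of (4-methoxyphenyl)sulfanyl on an aromatic carbon. Going by the values given here, no measured step between two compounds is available to size this change, and compound 3 itself gives only a limit.

Given that compound 1 and compound 2 show values in the weak range and compound 3 reports only (the limit of < 100000 nM in this assay, at which 1 of the 3 values shown sits), compound 4 is expected to stay in the same weak region, with the step that the limit leaves unreadable from compound 3 to compound 4 estimated as not beyond the scatter. For compound 4 the expected value in this assay is 50000 nM, with a range from 15000 nM to 150000 nM.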

Compound 4, concentration lethal to 50% of the cells: 83200 nM
For compound 4 the middle estimate is 1.7-fold (0.22 log units) below the measured one; measured number inside the range.
By their numbers in this assay, from the lowest: compounds 2, 1 and 4 (each within the scatter of the next, the first and the last beyond it).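

No step can be read from compound 3 to compound 4, since compound 3 stands only on a limit of the assay: the limit of < 100000 nM in this assay, at which 1 of the 4 values shown sits.

The compounds shown leave open where compound 3 lies within that limit, and so whether 4-fluorophenoxy in place of (4-methoxyphenyl)sulfanyl on an aromatic carbon changes the value in this assay at all.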